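Replacing Pyrazin-2-yl with 2-Chlorophenyl: an Expected Gain

The source may hold more compounds than are shown below. What is called first, only, known or untested is meant among the compounds shown, and "the series" means these compounds.

Measured compounds:
Compound 1 `Cc1nn(-c2nc(-c3ccc(Cl)c(Cl)c3)c(SC(C)C)s2)c(C(=O)O)c1-c1ccc(Cl)cc1` gives 2500 nM in a functional assay on BJAB cells (Homo sapiens) for antiproliferative activity, with a stated time of 4 days; a lower number here means that less compound is needed, a higher number that more compound is needed for the effect.
Compound 2 `Cc1nn(-c2nc(-c3ccc(Cl)c(Cl)c3)c(SC(C)C)s2)c(C(=O)O)c1-c1cccc(Cl)c1C` gives 5100 nM in this assay.
Compound 3 `Cc1nn(-c2nc(-c3ccc(Cl)c(Cl)c3)c(SC(C)C)s2)c(C(=O)O)c1-c1cnccn1` gives 14000 nM in this assay.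

Compound 3 stands highest of the three, as the steps of a 5.6-fold higher number from compound 1 to compound 3 (0.75 log units; beyond the scatter) and a 2.7-fold higher number from compound 2 to compound 3 (0.44 log units; beyond the scatter) show; the smaller step of a 2.0-fold higher number from compound 1 to compound 2 (0.31 log units; beyond the scatter) separates the two chlorinated phenyl analogues. Compound 4 `Cc1nn(-c2nc(-c3ccc(Cl)c(Cl)c3)c(SC(C)C)s2)c(C(=O)O)c1-c1ccccc1Cl` differs from compound 3 in one place: 2-chlorophenyl in place of pyrazin-2-yl on an aromatic carbon. The two steps that bear on this both run the other way, each swapping a chlorinated phenyl for pyrazin-2-yl and raising the number, by a modest margin in each case. A move back toward the chlorinated phenyl analogues is therefore expected to lower the number in this assay, somewhere between the sizes of those two steps, estimated at a 3.5-fold lower number from compound 3 to compound 4 (0.54 log units; beyond the scatter). Compound 4 is expected to give 4000 nM, within 1500 nM to 12000 nM.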

Compound 4, half-maximal effective concentration: 13100 nM
Compound 4: the middle estimate sits 3.3-fold (0.52 log units) below what was measured; the whole stated range lies below it.
By their numbers in this assay, from the lowest: compound 1; then compound 2; then compounds 4 and 3 (each within the scatter of the next).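

In this assay the swap of pyrazin-2-yl for 2-chlorophenyl at this position leaves the two compounds level (a 1.1-fold lower number from compound 3 to compound 4 (0.03 log units; within the scatter)), so a chlorinated phenyl here does not by itself give the lower numbers of the earlier analogues. The placement of the substituents on the phenyl ring counts instead, as 2-chlorophenyl stands apart from both 4-chlorophenyl (a 5.2-fold higher number from compound 1 to compound 4 (0.72 log units; beyond the scatter)) and 3-chloro-2-methylphenyl (a 2.6-fold higher number from compound 2 to compound 4 (0.41 log units; beyond the scatter)). No measurement shown here explains this result.

The compounds shown leave open how unsubstituted phenyl or 3-chlorophenyl would compare at this position. They also leave open whether 2-methylphenyl would stand with 2-chlorophenyl or with 3-chloro-2-methylphenyl.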